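Methoxy placement on the arylidene ring: expectation for compound 3

The source may report more compounds than this note shows. Statements on the series, on what has been measured and on what is new or still open speak of the compounds shown alone.

For the measured compounds named here, compound 2 `COc1cccc(/C=C2\CN(CC(=O)O)c3ccc(C)cc3C2=O)c1` gives 14.4% in an assay on HL-60 cells for inhibition of glutathione S-transferase P (Homo sapiens), read by spectrophotometry, tested at 20 uM (on this read-out higher numbers stand for more inhibition at the one concentration tested (going by the name of the read-out) and lower numbers for less inhibition), the lowest of the two numbers so far; its only comparator, compound 1 `COc1cc(/C=C2\CN(CC(=O)O)c3ccc(C)cc3C2=O)cc(OC)c1`, gives 23.8%, and the step of a number 9.4 percentage points lower from compound 1 to compound 2 (within the scatter) stays within the scatter. Compound 3 `COc1ccc(/C=C2\CN(CC(=O)O)c3ccc(C)cc3C2=O)cc1` differs from compound 2 by 4-methoxyphenyl in place of 3-methoxyphenyl on a double-bonded chain carbon bound to a double-bonded ring carbon. Going by the values given here, no measured step moves a methoxy group around the ring; the one step available, a methoxy removed, changed little. Accordingly no movement beyond the scatter is expected, and compound 3 is estimated at 18%, within 8% to 30%. The expected step is a number 3.6 percentage points higher from compound 2 to compound 3 (within the scatter).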

Compound 3, a percentage reported as inhibition, at one concentration (the size of the read-out at that concentration, not a potency): 17.5%
For compound 3 the middle estimate is 0.5 percentage points above the measured one; the range from low to high includes it.
By their numbers in this assay, from the lowest: compounds 2, 3 and 1 (each within the scatter of the next).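

In this assay, for the compounds shown here, the exchange of 3-methoxyphenyl for 4-methoxyphenyl gives a number 3.1 percentage points higher from compound 2 to compound 3 (within the scatter) and is the first step in which the methoxy group changes place rather than being removed. Going by these compounds alone, on this read-out the two placements are not told apart, so at this double-bonded chain carbon the series so far shows no dependence on where the single methoxy group sits. No evidence on the reason bears on this result.

Still open, going by these compounds, is 2-methoxyphenyl at the same carbon. Also open, on these data alone, is whether an amine or a hydroxyl group on that ring in place of methoxy would give a step beyond the scatter.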